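The source may hold more compounds than are shown below. What is called first, only, known or untested is meant among the compounds shown, and "the series" means these compounds.

Compound 3 `O=c1c2ccccc2[se]n1-c1nc(SCc2ccc(Cl)cc2)n[nH]1` carries the highest of the three numbers recorded so far in a functional assay on SMMC-7721 cells (Homo sapiens) for antiproliferative activity, read by CCK-8 assay, with a stated time of 48 h (a higher number here means a weaker inhibitor, a lower number a stronger inhibitor), where compound 3 gives 33900 nM. The two compounds beside it are compound 1 `O=c1c2ccccc2[se]n1-c1nc(SCc2ccccc2)n[nH]1`, which in this assay gives 32000 nM, and compound 2 `CCCCCCSc1n[nH]c(-n2[se]c3ccccc3c2=O)n1`, which in this assay gives 22400 nM. None of the three is separated from another by more than the usual scatter: a 1.1-fold higher number from compound 1 to compound 3 (0.03 log units; within the scatter), a 1.4-fold lower number from compound 1 to compound 2 (0.15 log units; within the scatter) and a 1.5-fold higher number from compound 2 to compound 3 (0.18 log units; within the scatter).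

Compound 4 `CC(C)Sc1n[nH]c(-n2[se]c3ccccc3c2=O)n1` differs from compound 3 by isopropyl in place of 4-chlorobenzyl on a sulfur. The measured steps that bear on this change are the ones that exchange the group attached to the same sulfur: a 1.5-fold higher number from compound 2 to compound 3 (0.18 log units; within the scatter), and a 1.4-fold lower number from compound 1 to compound 2 (0.15 log units; within the scatter), in which a chain took the place of an aromatic ring. For the measured compounds named here, both of these stayed within the scatter, and nothing among the measured compounds points to a different outcome when the 4-chlorobenzyl group gives way to a short branched alkyl group. Compound 4 is therefore expected to show no step beyond the scatter, a 1.2-fold lower number from compound 3 to compound 4 (0.08 log units; within the scatter). Compound 4 is estimated at 28000 nM in this assay, with a range from 12000 nM to 65000 nM.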

Compound 4, half-maximal inhibitory concentration: 6010 nM
The estimate for compound 4 lay 4.7-fold (0.67 log units) above the measured number; the measured number lies below the stated range.
By their numbers in this assay, from the lowest: compound 4; then compounds 2, 1 and 3 (each within the scatter of the next).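

In this assay, for the compounds shown here, the groups exchanged earlier on this sulfur stayed within the scatter of one another, whereas isopropyl is the first group there to bring a step beyond it, and it does so against all three earlier groups: against 4-chlorobenzyl (a 5.6-fold lower number from compound 3 to compound 4 (0.75 log units; beyond the scatter)), against hexyl (a 3.7-fold lower number from compound 2 to compound 4 (0.57 log units; beyond the scatter)) and against benzyl (a 5.3-fold lower number from compound 1 to compound 4 (0.73 log units; beyond the scatter)). The step from the hexyl compound is beyond the scatter as well, so the lower number does not depend on the loss of the aromatic ring alone, since compound 2 has no such ring on this sulfur and still gives way to compound 4. No measurement at hand explains this difference. The compounds shown leave open whether the lower number goes with the branching of isopropyl or with its shortness, as hexyl differs from it in both, and whether an ethyl, a propyl or a tert-butyl group on this sulfur would behave as isopropyl does. They also leave open whether a cyclopropyl group, or a short chain ending in an amine or a carboxylic acid, would hold the number of compound 4 or lose it.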